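Pyrrolidin-1-yl for Methoxy: Expected Half-Life of Compound 4

The compounds below may be only part of what the source reports. "The series", "measured", "known", "first", "only" and "open" are said of these compounds alone.

Of the compounds shown here, three on a shared core have been tested in an ADME assay on microsomes from liver (Mus musculus, strain CD-1) for metabolic stability, read by LC-MS, using NADPH, with a stated time of 60 min, tested at 1 uM; on this read-out higher numbers stand for a longer-lived compound and lower numbers for a shorter-lived compound. Compound 1 `CN(C)c1ccc(C2CCCN2Cc2ccc(-c3ccccc3[N+](=O)[O-])o2)cc1` gives 0.0158 h, compound 2 `O=[N+]([O-])c1ccccc1-c1ccc(CN2CCCC2c2ccc(N3CCCCC3)cc2)o1` gives 0.0215 h, and compound 3 `COc1ccc(C2CCCN2Cc2ccc(-c3ccccc3[N+](=O)[O-])o2)cc1` gives 0.0122 h. The three numbers sit close together: the step of a 1.4-fold higher number from compound 1 to compound 2 (0.13 log units; within the scatter) and the step of a 1.3-fold lower number from compound 1 to compound 3 (0.11 log units; within the scatter) are both within the scatter, as is the step of a 1.8-fold lower number from compound 2 to compound 3 (0.25 log units; within the scatter). Compound 3 therefore cannot be set apart from compound 1 or compound 2 on these numbers.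

Compound 4 `O=[N+]([O-])c1ccccc1-c1ccc(CN2CCCC2c2ccc(N3CCCC3)cc2)o1` is now to be measured in this assay. It differs from compound 3 in one place: pyrrolidin-1-yl in place of methoxy on an aromatic carbon. Among the measured compounds shown here, the steps that bear on this change are those in which an amino-type group stands where methoxy does in compound 3, namely the step of a 1.3-fold lower number from compound 1 to compound 3 (0.11 log units; within the scatter) and the step of a 1.8-fold lower number from compound 2 to compound 3 (0.25 log units; within the scatter); both are within the scatter. On that basis the step from compound 3 to compound 4 is expected to be small, at most in the direction of a slightly higher number, and the estimated step is a 1.5-fold higher number from compound 3 to compound 4 (0.17 log units; within the scatter). Compound 4 is thus expected to give about 0.018 h in this assay, with a range from 0.009 h to 0.036 h.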

Compound 4, half-life: 0.0445 h
Beside the measured number, compound 4's estimate is 2.5-fold (0.39 log units) below it; measured number outside the range, above it.
By their numbers in this assay, from the lowest: compounds 3, 1 and 2 (each within the scatter of the next); then compound 4.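

In this assay, among the compounds shown here, the earlier compounds gave no sign that the group at this position mattered, since dimethylamino, piperidin-1-yl and methoxy all lay within the scatter of one another. Pyrrolidin-1-yl is the one group shown that stands clear of the others, with a 3.6-fold higher number from compound 3 to compound 4 (0.56 log units; beyond the scatter), a 2.8-fold higher number from compound 1 to compound 4 (0.45 log units; beyond the scatter) and a 2.1-fold higher number from compound 2 to compound 4 (0.32 log units; beyond the scatter). An amine nitrogen on this aromatic carbon is therefore not enough by itself to set a compound apart from the methoxy compound: compound 1 and compound 2 also carry one and stay within the scatter of compound 3, and the data offer no measured evidence that accounts for what distinguishes pyrrolidin-1-yl.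

The compounds shown leave open whether the longer half-life belongs to the five-membered ring in particular, or whether a smaller ring such as azetidin-1-yl or a ring with a second hetero atom such as morpholin-4-yl would give a similar number. They also leave open whether the same step would appear if a group such as a nitrile stood in place of the nitro group elsewhere on the shared core.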